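The source may hold more compounds than are shown below. What is called first, only, known or untested is meant among the compounds shown, and "the series" means these compounds.

Of the compounds shown here, three from one series have been tested in an in vitro ADME assay on microsomes from liver (Mus musculus) for metabolic stability; a lower number here means slower removal, a higher number faster removal of the compound. Compound 1, `Cc1cc(Nc2ccc(S(F)(F)(F)(F)F)cc2)n2nc(C3CC3)nc2n1`, gives 12.6 mL.min-1.g-1. Among the measured compounds shown here, compound 2, `CCC(F)(F)c1nc2nc(C)cc(Nc3ccc(S(F)(F)(F)(F)F)cc3)n2n1`, gives 6.7 mL.min-1.g-1; the single step between measured neighbours, a 1.9-fold lower number from compound 1 to compound 2 (0.27 log units; within the scatter), stays within the scatter. Compound 3, `CCc1nc2nc(C)cc(Nc3ccc(C(F)(F)F)cc3)n2n1`, gives 14.4 mL.min-1.g-1, the highest of the three numbers, though its gap to compound 1 lies within the scatter, while the gap to compound 2 lies beyond it.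

Compound 4 is `CCOc1nc2nc(C)cc(Nc3ccc(C(F)(F)F)cc3)n2n1`. The change from compound 3 is ethoxy in place of ethyl on an aromatic carbon. For the measured compounds named here, no measured step touches this kind of exchange: the only step on hand swaps cyclopropyl for 1,1-difluoropropyl, a different position and a different pair of groups, and it stayed within the scatter. With nothing in the data pointing in either direction, the expectation is that the exchange of ethyl for ethoxy leaves the number where compound 3 stands, within the scatter. For compound 4 the estimated step is a 1.0-fold higher number from compound 3 to compound 4 (0.02 log units; within the scatter), so compound 4 is expected to give 15 mL.min-1.g-1 in this assay, between 7.5 mL.min-1.g-1 and 30 mL.min-1.g-1.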

Compound 4, intrinsic clearance in microsomes: 14.4 mL.min-1.g-1
Estimate against measurement, compound 4: 1.0-fold (0.02 log units) above, and the stated range covers the measured number.
By their numbers in this assay, from the lowest: compounds 2, 1, 3 and 4 (each within the scatter of the next, the first and the last beyond it).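

In this assay, putting ethoxy in place of ethyl on the aromatic carbon between two ring nitrogen atoms gives no change at the digits printed from compound 3 to compound 4 (within the scatter). Among the compounds shown here, the only earlier step exchanged cyclopropyl for 1,1-difluoropropyl, neither of which holds an oxygen atom, so this pair is the first sign that a group attached through oxygen can sit on this carbon without moving the number beyond the scatter. No measurement on hand explains why the number holds.

From the compounds shown here alone, whether the same is true of an amine such as dimethylamino, or of a longer chain such as butoxy, on this carbon remains open. Going by these compounds, it is also open whether ethoxy would behave the same way on the compounds carrying the pentafluorosulfanyl group, such as compound 1 and compound 2.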